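Chain extension on compound 1: working notes

The source may hold more compounds than are shown below. What is called first, only, known or untested is meant among the compounds shown, and "the series" means these compounds.

Values in a functional assay on brain (Rattus norvegicus, strain Wistar) for inhibition; on this read-out higher numbers stand for weaker inhibition and lower numbers for stronger inhibition
compound 1 `CCCCOc1ccc(-c2c(C)[nH]c(=O)n2C)cc1` gives 5100 nM
compound 2 `Cc1[nH]c(=O)n(C)c1-c1ccc(CC(C)C)cc1` gives 7800 nM
compound 3 `CCCCCCCc1ccc(-c2c(C)[nH]c(=O)n2C)cc1` gives 8400 nM

Compound 1 stands within the scatter of both other compounds, as a 1.5-fold higher number from compound 1 to compound 2 (0.18 log units; within the scatter) and a 1.6-fold higher number from compound 1 to compound 3 (0.22 log units; within the scatter) show. The step to compound 4 `CCCCCCCCCCOc1ccc(-c2c(C)[nH]c(=O)n2C)cc1` is hexyl in place of hydrogen on a saturated chain carbon, four bonds along the chain from an oxygen on an aromatic ring and the same difference reads methyl to heptyl. Among the measured compounds shown here, no measured step lengthens the butoxy chain itself. The nearest evidence is a 1.1-fold higher number from compound 2 to compound 3 (0.03 log units; within the scatter) with hexyl in place of isopropyl, and the heptyl for butoxy step above likewise stays within the scatter. In this assay the expected size is a 1.2-fold higher number from compound 1 to compound 4 (0.07 log units; within the scatter) and no step beyond the scatter is anticipated. Compound 4 is expected at 6000 nM with an estimated range of 2000 nM to 18000 nM for now.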

Compound 4, half-maximal inhibitory concentration: 6900 nM
Compound 4: middle estimate off by 1.2-fold (0.06 log units), on the low side, and the stated range covers the measured number.
By their numbers in this assay, from the lowest: compounds 1, 4, 2 and 3 (each within the scatter of the next).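

Hexyl in place of hydrogen on a saturated chain carbon, four bonds along the chain from an oxygen on an aromatic ring, gives a 1.4-fold higher number from compound 1 to compound 4 (0.13 log units; within the scatter) in this assay. Among the compounds shown here, this is the only direct reading on lengthening the butoxy chain itself, and at this place the added hexyl leaves the number within the scatter. Nothing shown gives a reason for this result.

Still open, on these data alone, is whether an amine or a carboxylic acid in place of the hexyl would give a step beyond the scatter in this assay. No step shown so far leaves the scatter, so the limits of change at this place remain undefined.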